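Thiophen-2-yl for furan-2-yl at the assay limit

The compounds below may be only part of what the source reports. "The series", "measured", "known", "first", "only" and "open" are said of these compounds alone.

Compound 1 `O=c1[nH]cnc2c1c(-c1ccccc1)cn2[C@@H]1O[C@H](CO)[C@@H](O)[C@H]1O`: > 20000 nM
Compound 2 `Nc1nc(N)c2c(-c3ccco3)cn([C@@H]3O[C@H](CO)[C@@H](O)[C@H]3O)c2n1`: > 20000 nM

Both compounds were tested in a functional assay on HCT-116 cells (Homo sapiens), read by MTT assay, with a stated time of 72 h (a higher number here means a weaker inhibitor, a lower number a stronger inhibitor), and neither gave a number. Compound 2 reached only a limit, > 20000 nM. Compound 1 also reached only a limit, > 20000 nM. The two therefore stand together at the limit of > 20000 nM in this assay, at which 2 of the 2 values shown sit, and no order can be read from them.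

Compound 3 `Nc1nc(N)c2c(-c3cccs3)cn([C@@H]3O[C@H](CO)[C@@H](O)[C@H]3O)c2n1` keeps the core of compound 2 but carries thiophen-2-yl in place of furan-2-yl on an aromatic carbon. Among the measured compounds shown here, no measured step shows what such a change does in this assay. The expectation rests on compound 2, whose value > 20000 nM is a limit. No step beyond the usual scatter is expected, and another limit is the likeliest report. The estimated step is a number no higher from compound 2 to compound 3 (the limit leaves the size open). For compound 3 the expected value is 20000 nM, with an estimated range from 4000 nM to 40000 nM.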

Compound 3, half-maximal inhibitory concentration: > 20000 nM
Compound 3: no number, only a limit; the forecaster's own chance of this, stated with the estimate: 70%; the middle value lies on the limit itself.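

Among the compounds shown here, compound 3 also gave only a limit, > 20000 nM, so no step from compound 2, itself at a limit, can be read in this assay. The compounds shown leave open whether thiophen-2-yl and furan-2-yl differ at all in this assay, since all three stand together: the limit of > 20000 nM in this assay, at which 3 of the 3 values shown sit.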